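The compounds below may be only part of what the source reports. "The series", "measured", "known", "first", "only" and "open" are said of these compounds alone.

Compound 1 `COc1ccc(-c2cc(C(=O)Nc3nc4ccc(F)cc4s3)nc3cc(-c4ccccc4)nn23)cc1OC` and compound 2 `COc1cc(-c2cc(C(=O)Nc3nc4ccc(F)cc4s3)nc3cc(-c4ccccc4)nn23)cc(OC)c1OC` share a core and differ in one place: methoxy in place of hydrogen on an aromatic carbon. In a functional assay on ACHN cells (Homo sapiens) for cytotoxicity, read by MTT assay, with a stated time of 48 h (on this read-out lower numbers stand for stronger inhibition and higher numbers for weaker inhibition), compound 1 gives 8120 nM, and compound 2 gives 32400 nM, so that a 4.0-fold higher number from compound 1 to compound 2 (0.60 log units; beyond the scatter). Compound 3 `COc1ccc(-c2cc(C(=O)Nc3nc4cc(C)c(C)cc4s3)nc3cc(-c4ccccc4)nn23)cc1` carries a different core; the difference between the two cores is not broken down here. In this assay compound 3 gives 22400 nM. Compound 4 `COc1ccc(-c2cc(C(=O)Nc3nc4cc(C)c(C)cc4s3)nc3cc(-c4ccccc4)nn23)cc1OC` is drawn from compound 3 by the same kind of change, (methoxy in place of hydrogen on an aromatic carbon), though here the place is not also meta to a methoxy group. Going by the values given here, since the only measured example, the step from compound 1 to compound 2, sits on the other core, the estimate for compound 4 is cautious: the step of a 1.1-fold higher number from compound 3 to compound 4 (0.05 log units; within the scatter) is expected, and compound 4 is expected to give 25000 nM, between 8000 nM and 80000 nM.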

Compound 4, half-maximal inhibitory concentration: 8700 nM
Compound 4: middle estimate off by 2.9-fold (0.46 log units), on the high side, and the stated range covers the measured number.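

With 5,6-dimethyl-1,3-benzothiazol-2-yl on the amide nitrogen, the change from 4-methoxyphenyl to 3,4-dimethoxyphenyl gives a 2.6-fold lower number from compound 3 to compound 4 (0.41 log units; beyond the scatter) in this assay, and the same kind of change on the other core runs the opposite way: the same change on two cores in this assay, a 4.0-fold higher number (0.60 log units; beyond the scatter) from compound 1 to compound 2 and a 2.6-fold lower number (0.41 log units; beyond the scatter) from compound 3 to compound 4, 10-fold (1.01 log units) apart, beyond the scatter of two such steps. So neither the size nor the direction of a methoxy step carries over between these two cores, but two pairs, with the added methoxy placed differently on the ring, do not show what decides the outcome. With the 3,4-dimethoxyphenyl group kept, 5,6-dimethyl-1,3-benzothiazol-2-yl in place of 6-fluoro-1,3-benzothiazol-2-yl gives a 1.1-fold higher number from compound 1 to compound 4 (0.03 log units; within the scatter), so this pair cannot be told apart here.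

Going by these compounds, it remains open whether a hydroxyl group or an amine at the same place on the ring would behave as the methoxy does on either core.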